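The compounds below may be only part of what the source reports. "The series", "measured", "known", "first", "only" and "open" are said of these compounds alone.

Measured so far:
- compound 1 `Cc1nc(N)c2c(-c3cccs3)cn([C@@H]3O[C@H](CO)[C@@H](O)[C@H]3O)c2n1`: > 20000 nM
- compound 2 `CSc1ncnc2c1c(-c1cccs1)cn2[C@@H]1O[C@H](CO)[C@@H](O)[C@H]1O`: 1130 nM

In a functional assay on HL-60 cells (Homo sapiens) for antiproliferative activity, read by XTT assay, with a stated time of 72 h (on this read-out higher numbers stand for weaker inhibition and lower numbers for stronger inhibition), compound 1 gives only a limit, > 20000 nM, with no number behind it (the limit of > 20000 nM in this assay, at which 1 of the 2 values shown sits). Compound 2 gives a number, 1130 nM, in this assay. Compound 3 `C#Cc1cn([C@@H]2O[C@H](CO)[C@@H](O)[C@H]2O)c2nc(C)nc(N)c12` is not yet measured. It differs from compound 1 by ethynyl in place of thiophen-2-yl on an aromatic carbon. For the measured compounds named here, no measured step of this kind is available, so the size of the change is an open guess; the expectation is for little movement, a number no higher from compound 1 to compound 3 (the limit leaves the size open), and compound 3 is estimated at 20000 nM (range 5000 nM to 60000 nM), quite possibly again reported as a limit.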

Compound 3, half-maximal inhibitory concentration: > 20000 nM
Compound 3 gave a limit, no number (the forecaster's own chance of this, stated with the estimate: 60%); the middle value lies on the limit itself.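

Compound 1 and compound 3 both end at a limit in this assay, so ethynyl in place of thiophen-2-yl gives no readable step: the limit of > 20000 nM in this assay, at which 2 of the 3 values shown sit. Still open, as far as these compounds go, is whether this change moves antiproliferative activity at all, since neither compound has a number.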